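Methoxy to hydroxy step carried to a second core

A few compounds are considered here, and "the series" means these few. Any claim that something is new, unique, unknown or untested is made for them only; others in the source may bear on it.

Measured in a functional assay on SK-OV-3 cells (Homo sapiens) for inhibition, read by sulforhodamine B assay, with a stated time of 48 h; on this read-out higher numbers stand for weaker inhibition of growth and lower numbers for stronger inhibition of growth:
- compound 1 `COc1cc(-c2nn(-c3cccc(NC(=O)Nc4cc(C(F)(F)F)cc(C(F)(F)F)c4)c3)cc2-c2ccncc2)ccc1Cl`: 2570 nM
- compound 2 `O=C(Nc1cccc(-n2cc(-c3ccncc3)c(-c3ccc(Cl)c(O)c3)n2)c1)Nc1cc(C(F)(F)F)cc(C(F)(F)F)c1`: 3810 nM
- compound 3 `COc1cc(-c2nn(-c3cccc(NC(=O)Nc4ccc(Cl)c(C(F)(F)F)c4)c3)cc2-c2ccncc2)ccc1Cl`: 13000 nM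

Compound 1 and compound 2 share a core and differ only by hydrogen in place of methyl on an oxygen on an aromatic ring. In this assay this gives a 1.5-fold higher number from compound 1 to compound 2 (0.17 log units; within the scatter), so the two sit within the usual scatter and no order between them is claimed.

Compound 3 carries a different core; how it differs from compound 1 is not broken down here. In this assay compound 3 stands highest of the three, and its gaps to compound 2 and to compound 1 both lie beyond the scatter.

Compound 4 `O=C(Nc1cccc(-n2cc(-c3ccncc3)c(-c3ccc(Cl)c(O)c3)n2)c1)Nc1ccc(Cl)c(C(F)(F)F)c1` differs from compound 3 by hydrogen in place of methyl on an oxygen on an aromatic ring. This is the same change at the same place as that from compound 1 to compound 2.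

Resting on the single earlier instance, a 1.5-fold higher number from compound 1 to compound 2 (0.17 log units; within the scatter), a step of a 1.3-fold higher number from compound 3 to compound 4 (0.12 log units; within the scatter) is expected in this assay. Compound 4 is therefore estimated to give 17000 nM in this assay, with a likely range from 8000 nM to 40000 nM. With one prior example, this expectation is weakly founded.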

Compound 4, concentration for total growth inhibition: 14900 nM
Estimate against measurement, compound 4: 1.1-fold (0.06 log units) above; measured number inside the range.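

In this assay, replacing methoxy with hydroxy on the aromatic ring gives (a 1.1-fold higher number from compound 3 to compound 4 (0.06 log units; within the scatter)), and the step agrees with the earlier one on the other core: the same change on two cores in this assay, a 1.5-fold higher number (0.17 log units; within the scatter) from compound 1 to compound 2 and a 1.1-fold higher number (0.06 log units; within the scatter) from compound 3 to compound 4, 1.3-fold (0.11 log units) apart, within the scatter of two such steps.

Across these two matched pairs, the methoxy and hydroxy forms are not separated in this assay, so on the evidence here the change carries from the core of compound 1 to the core of compound 3 without a readable shift in either. Going by these compounds alone, this rests on only two pairs, both with the 4-chloro-3-methoxyphenyl to 4-chloro-3-hydroxyphenyl swap, and it does not show that the change would behave the same way on any further core, in any other assay, or at any other place on these molecules.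

The compounds shown leave open whether a longer chain on that oxygen, such as ethoxy, or an amine in place of the hydroxy would also stay within the scatter. They also leave open how a carboxylic acid at this place would read on either core.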